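The compounds below may be only part of what the source reports. "The series", "measured", "known", "first", "only" and "open" are said of these compounds alone.

In a functional assay on HeLa cells (Homo sapiens) for cytotoxicity, with a stated time of 72 h (a higher number here means a weaker inhibitor, a lower number a stronger inhibitor), the three measured compounds gave these numbers:

Compound 1 `CCCC#Cc1cn([C@@H]2O[C@H](CO)[C@@H](O)[C@H](O)[C@H]2O)c(=O)[nH]c1=O`: 95000 nM
Compound 2 `O=c1[nH]c(=O)n([C@@H]2O[C@H](CO)[C@@H](O)[C@H](O)[C@H]2O)cc1CCc1ccccc1`: 43000 nM
Compound 3 `O=c1[nH]c(=O)n([C@@H]2O[C@H](CO)[C@@H](O)[C@H](O)[C@H]2O)cc1C#Cc1ccccn1`: 66000 nM

Compound 3 holds the second highest of the three numbers, and both of its neighbours sit within the scatter, as a 1.4-fold lower number from compound 1 to compound 3 (0.16 log units; within the scatter) and a 1.5-fold higher number from compound 2 to compound 3 (0.19 log units; within the scatter) show. Compound 4 `O=c1[nH]c(=O)n([C@@H]2O[C@H](CO)[C@@H](O)[C@H](O)[C@H]2O)cc1C#Cc1cccnc1` differs from compound 3 by one change: pyridin-3-yl in place of pyridin-2-yl on a triple-bonded carbon. Among the measured compounds shown here, no measured step exchanges one pyridinyl for another. The nearest is a 1.4-fold lower number from compound 1 to compound 3 (0.16 log units; within the scatter), which stayed within the scatter, while a 2.2-fold lower number from compound 1 to compound 2 (0.34 log units; beyond the scatter) was only modest. Relative to compound 3, compound 4 is expected to show a 1.1-fold lower number from compound 3 to compound 4 (0.04 log units; within the scatter), that is, no step beyond the scatter. Compound 4 is estimated at 60000 nM, between 25000 nM and 150000 nM.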

Compound 4, half-maximal inhibitory concentration: > 250000 nM
Compound 4: a limit, no number; the forecaster's own chance of this, stated with the estimate: 20%; middle value at least 4.1-fold (0.61 log units) away from the limit.
By their numbers in this assay, from the lowest: compounds 2, 3 and 1 (each within the scatter of the next, the first and the last beyond it). At a limit, above all of these: compound 4.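

Swapping pyridin-2-yl for pyridin-3-yl on a triple-bonded carbon keeps the same atoms, yet it gives an at least 3.7-fold higher number from compound 3 to compound 4 (0.57 log units; beyond the scatter), so this position responds even when only the way the group is joined changes. Among the compounds shown here, compound 4 also stands apart from the other two compounds, with an at least 5.8-fold higher number from compound 2 to compound 4 (0.76 log units; beyond the scatter) and an at least 2.6-fold higher number from compound 1 to compound 4 (0.42 log units; beyond the scatter), whereas the earlier steps were modest at most. In this assay compound 4 gives a limit, not a number: the limit of > 250000 nM in this assay, at which 1 of the 4 values shown sits.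

From the compounds shown here alone, the full size of these steps stays open. So does whether pyridin-4-yl on the triple-bonded carbon would behave like pyridin-2-yl or like pyridin-3-yl.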